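The source may hold more compounds than are shown below. What is called first, only, known or untested is meant among the compounds shown, and "the series" means these compounds.

In a functional assay on MDA-MB-231 cells (Homo sapiens) for cytotoxicity, read by MTT assay, with a stated time of 48 h (a higher number here means a weaker inhibitor, a lower number a stronger inhibitor), compound 1 `O=C(NCCCCC(c1ccc(F)cc1)c1ccc(F)cc1)Nc1ccc(Cl)cc1` gives 7680 nM. Compound 2 `O=C(NCCCCC(c1ccc(F)cc1)c1ccc(F)cc1)Nc1ccc([N+](=O)[O-])cc1`, which has the same core, gives 6470 nM, so the two stand level within the usual scatter. Compound 3 `CC(=O)Nc1ccc(NC(=O)NCCCCC(c2ccc(F)cc2)c2ccc(F)cc2)cc1` has acetamido in place of nitro on an aromatic carbon, para to a large group: acetamido in place of nitro on an aromatic carbon. Going by the values given here, only one measured step bears on this change. It is the swap of nitro in place of chloro at the same place, a 1.2-fold lower number from compound 1 to compound 2 (0.07 log units; within the scatter), and it shows no shift that can be told from the scatter. Among the compounds with values here, that is thin evidence, as no measured compound carries acetamido or any similar group here. A clear move in either direction is therefore not expected in this assay. The expected step is a 1.2-fold higher number from compound 2 to compound 3 (0.09 log units; within the scatter). For compound 3 the estimated value is 8000 nM, with an expected range of 3000 nM to 25000 nM.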

Compound 3, half-maximal inhibitory concentration: > 20000 nM
Compound 3: a limit, no number; the forecaster's own chance of this, stated with the estimate: 10%; middle value at least 2.5-fold (0.39 log units) away from the limit.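

Chloro and nitro on this aromatic carbon could not be told apart, but this position does respond to the group it carries: acetamido gives an at least 3.0-fold higher number from compound 2 to compound 3 (0.49 log units; beyond the scatter), and in place of chloro it gives an at least 2.6-fold higher number from compound 1 to compound 3 (0.41 log units; beyond the scatter). Going by these compounds alone, a higher number here means a weaker inhibitor, so compound 3 is weaker than both of the others, and the change from nitro to acetamido is the first on this carbon to rise beyond the scatter. The value of compound 3 is a limit and not a number: the limit of > 20000 nM in this assay, at which 1 of the 3 values shown sits.

The compounds shown leave open how much weaker compound 3 really is, and whether the weaker result goes with the hydrogen-bond donor of acetamido or with its extra heavy atoms. An amine or a methoxy group on this aromatic carbon would help to separate those two possibilities.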